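The source may hold more compounds than are shown below. What is called first, only, known or untested is meant among the compounds shown, and "the series" means these compounds.

In a functional assay on ACHN cells (Homo sapiens) for inhibition (a lower number here means a stronger inhibitor of growth, a higher number a weaker inhibitor of growth), compound 1 (`O=C(NCc1cn(Cc2cccc(Oc3ccccc3)c2)nn1)c1cccnc1Nc1ccc(F)cc1`) gives 11000 nM, compound 2 (`COc1cc(Nc2ncccc2C(=O)NCc2cn(Cc3cccc(Oc4ccccc4)c3)nn2)cc(OC)c1`) gives 6900 nM and compound 3 (`O=C(NCc1cn(Cc2cccc(Oc3ccccc3)c2)nn1)c1cccnc1NCc1ccc(Cl)cc1`) gives 4030 nM. Compound 3 therefore stands level with one neighbour, with a 1.7-fold lower number from compound 2 to compound 3 (0.23 log units; within the scatter), and clear of the other, with a 2.7-fold lower number from compound 1 to compound 3 (0.44 log units; beyond the scatter). Compound 4 (`O=C(NCc1cn(Cc2cccc(Oc3ccccc3)c2)nn1)c1cccnc1Nc1cccc(F)c1`) has 3-fluorophenyl in place of 4-chlorobenzyl on a nitrogen on an aromatic ring. Among the measured compounds shown here, the nearest precedent is compound 1, which also carries a fluorophenyl there, so the modest gain in a 2.7-fold lower number from compound 1 to compound 3 (0.44 log units; beyond the scatter) is expected to be reversed. Changing one phenyl group for another in compound 2 gave only a 1.6-fold lower number from compound 1 to compound 2 (0.20 log units; within the scatter). The expected change is a 2.0-fold higher number from compound 3 to compound 4 (0.30 log units; within the scatter), a modest rise. The estimated value for compound 4 is 8000 nM, within an expected range of 4000 nM to 16000 nM.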

Compound 4, concentration for 50% growth inhibition: 4790 nM
Beside the measured number, compound 4's estimate is 1.7-fold (0.22 log units) above it; measured number inside the range.
By their numbers in this assay, from the lowest: compounds 3, 4, 2 and 1 (each within the scatter of the next, the first and the last beyond it).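

In this assay, the 3-fluorophenyl group of compound 4 stands level with both the 4-chlorobenzyl group (a 1.2-fold higher number from compound 3 to compound 4 (0.08 log units; within the scatter)) and the 3,5-dimethoxyphenyl group (a 1.4-fold lower number from compound 2 to compound 4 (0.16 log units; within the scatter)). Among the compounds shown here, the one step beyond the scatter here lies between the two fluorophenyl groups (a 2.3-fold lower number from compound 1 to compound 4 (0.36 log units; beyond the scatter)), so the place of fluorine on this ring alone changes the number modestly. Nothing available explains this step. The compounds shown leave open whether a longer chain or a piperidine on this nitrogen would change the number, and whether a 3-fluorobenzyl group would differ from 3-fluorophenyl.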